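Trifluoromethoxy in place of trifluoromethyl: notes on compound 4

The compounds below may be only part of what the source reports. "The series", "measured", "known", "first", "only" and "open" are said of these compounds alone.

For the measured compounds named here, of three compounds sharing one core, only one carries a number in a functional assay on Jurkat cells (Homo sapiens) for cytotoxicity, read by luminescence and CellTiter-Glo, with a stated time of 3 days; a lower number here means a stronger inhibitor, a higher number a weaker inhibitor. Compound 1 `N#Cc1cccc(NC(=O)c2cc(F)ccc2O)c1` stands at "not determined" (no result reported). Compound 2 `O=C(Nc1ccccc1)c1cc(F)ccc1O` stands at "not determined" (no result reported). Going by the values given here, compound 3 `O=C(Nc1cccc(C(F)(F)F)c1)c1cc(F)ccc1O` gives 840 nM, the only number available, so it cannot yet be ranked against any other compound.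

Compound 4 `O=C(Nc1cccc(OC(F)(F)F)c1)c1cc(F)ccc1O` is next in this assay. It differs from compound 3 by a single swap, trifluoromethoxy in place of trifluoromethyl on an aromatic carbon. The shared core stays unchanged. Among the compounds with values here, no measured step between any two compounds exists, so nothing yet shows how activity responds to a change at this place. Within the data shown here, the sole anchor is compound 3 at 840 nM. No direction is favoured, and the expected move is no larger than the usual scatter: the expected step is a 1.1-fold lower number from compound 3 to compound 4 (0.02 log units; within the scatter). For compound 4 the estimated value is 800 nM, with an expected range from 320 nM to 2000 nM.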

Compound 4, half-maximal inhibitory concentration: 700 nM
For compound 4 the middle estimate is 1.1-fold (0.06 log units) above the measured one, and the stated range covers the measured number.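

For the compounds shown here, this is the first step that can be read: in this assay the swap to trifluoromethoxy on this aromatic carbon gives a 1.2-fold lower number from compound 3 to compound 4 (0.08 log units; within the scatter) and stays within the scatter. At this position, the oxygen entering with trifluoromethoxy therefore leaves the read-out indistinguishable from that with trifluoromethyl, so this pair gives no reason to prefer either group. No measured property of either group is available to bear on this result.

Going by these compounds, compounds 1 and 2 carry no number, so steps involving them cannot be read, and the effect of nitrile or of an unsubstituted aromatic ring remains unknown. Also open, on these data alone, is how an amine, a carboxylic acid or a longer chain such as butoxy would read on this aromatic carbon, and whether any change to the shared core would move the number beyond the scatter.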